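A Solubility Limit Shared by Two Compounds

The source may hold more compounds than are shown below. What is called first, only, known or untested is meant among the compounds shown, and "the series" means these compounds.

Solubility describes how much of a compound stays dissolved, and two compounds have been tested for it so far. In a physicochemical assay for solubility, read by LC-MS, in phosphate buffer, with a stated time of 24 h, at pH 7.4 (on this read-out lower numbers stand for lower solubility and higher numbers for higher solubility), compound 1 `Cc1ncccc1-c1cnc(NCc2c(F)ccc3c2CCO3)c2n[nH]c(=O)n12` gives < 2000 nM, which is a limit of the assay and not a number. Compound 2 `CC(=O)N1CCC(c2cnc(NCc3c(F)ccc4c3CCO4)c3cn[nH]c(=O)c23)CC1` gives < 2000 nM, and this too is a limit and not a number. Compound 2 therefore stands at the limit of < 2000 nM in this assay, at which 2 of the 2 values shown sit.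

Compound 3 `CNC(=O)c1ncc(-c2cnc(NCc3c(F)ccc4c3CCO4)c3cn[nH]c(=O)c23)n1C` has not yet been measured. Compared with compound 2, it carries 1-methyl-2-(methylcarbamoyl)-1H-imidazol-5-yl in place of 1-acetylpiperidin-4-yl on an aromatic carbon. Among the measured compounds shown here, no measured pair shows what such a swap does, so no shift beyond the usual scatter is expected in this assay. The estimate amounts to a step that the limit leaves unreadable from compound 2 to compound 3, which is an expected step and not an observed one. This expectation leans on compound 2, whose limit is < 2000 nM. Compound 3 is expected at about 1400 nM, with an estimated range of 500 nM to 3000 nM.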

Compound 3, solubility: 5000 nM
The estimate for compound 3 lay 3.6-fold (0.55 log units) below the measured number; measured number outside the range, above it.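

In this assay, placing 1-methyl-2-(methylcarbamoyl)-1H-imidazol-5-yl instead of 1-acetylpiperidin-4-yl on this aromatic carbon gives an at least 2.5-fold higher number from compound 2 to compound 3 (0.39 log units; beyond the scatter), so this is the first change shown to move the read-out beyond the usual scatter. The group at this place, para to a large group, therefore matters for the number obtained, even though the rest of the molecule stays the same. The true size of the step cannot be read and only its lower bound is known, because compound 2 gives a limit and not a number: the limit of < 2000 nM in this assay, at which 2 of the 3 values shown sit.

The swap changes several things at once: a six-membered non-aromatic ring gives way to a five-membered aromatic ring, and the counts of hydrogen-bond donors and acceptors also differ, so this single pair cannot show which of these differences goes with the higher number. Going by these compounds, it also remains open how the read-out would respond to other groups at this place, such as an amine or a carboxylic acid.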